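The source may hold more compounds than are shown below. What is called first, only, known or untested is meant among the compounds shown, and "the series" means these compounds.

Measured in a functional assay on QGY-7703 cells (Homo sapiens) for cytotoxicity, read by MTT assay, with a stated time of 24 h; a lower number here means a stronger inhibitor, a higher number a weaker inhibitor:
- compound 1 `O=C1/C(=C/c2ccncc2)CN(S(=O)(=O)c2ccc([N+](=O)[O-])cc2)C/C1=C\c1ccccc1C(F)(F)F`: 9730 nM
- compound 2 `O=C1/C(=C/c2ccncc2)CN(S(=O)(=O)c2ccc(C(F)(F)F)cc2)C/C1=C\c1ccccc1C(F)(F)F`: 4680 nM
- compound 3 `O=C1/C(=C/c2ccncc2)CN(S(=O)(=O)c2ccc(Cl)cc2)C/C1=C\c1ccccc1C(F)(F)F`: 12700 nM

Compound 3, at 12700 nM, cannot be told apart from compound 1, as a 1.3-fold higher number from compound 1 to compound 3 (0.12 log units; within the scatter) shows. It is weaker than compound 2, as a 2.7-fold higher number from compound 2 to compound 3 (0.43 log units; beyond the scatter) shows.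

The next compound is compound 4 `CC(=O)Nc1ccc(S(=O)(=O)N2C/C(=C\c3ccncc3)C(=O)/C(=C/c3ccccc3C(F)(F)F)C2)cc1`. Here acetamido takes the place of chloro on an aromatic carbon, para to a large group: acetamido in place of chloro on an aromatic carbon.

The measured steps that bear on this are the swaps among the other groups at that same place: a 2.1-fold lower number from compound 1 to compound 2 (0.32 log units; beyond the scatter), a 1.3-fold higher number from compound 1 to compound 3 (0.12 log units; within the scatter) and a 2.7-fold higher number from compound 2 to compound 3 (0.43 log units; beyond the scatter). The largest of these is modest. Among the measured compounds shown here, none of the measured compounds carries acetamido, so these steps offer only a rough guide to size and none to direction. In this assay, a step no larger than modest is therefore expected, quite possibly none beyond the scatter.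

The expected change is a 1.3-fold lower number from compound 3 to compound 4 (0.10 log units; within the scatter). For compound 4 the estimate is 10000 nM, with an expected range of 4000 nM to 25000 nM.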

Compound 4, half-maximal inhibitory concentration: 5560 nM
For compound 4 the middle estimate is 1.8-fold (0.25 log units) above the measured one; the range from low to high includes it.
By their numbers in this assay, from the lowest: compounds 2, 4, 1 and 3 (each within the scatter of the next, the first and the last beyond it).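

In this assay, acetamido brings more heavy atoms and a hydrogen-bond donor where chloro has neither, and the swap gives (a 2.3-fold lower number from compound 3 to compound 4 (0.36 log units; beyond the scatter)), so this position takes the larger group with no loss of strength. Compound 4 cannot be told apart from the other two compounds, as shown by (a 1.2-fold higher number from compound 2 to compound 4 (0.07 log units; within the scatter)) and (a 1.8-fold lower number from compound 1 to compound 4 (0.24 log units; within the scatter)). Across these four groups, then, the position has so far produced only modest steps, and a group with an amide hydrogen falls inside that same narrow span.

No measurement here explains why acetamido gives a lower number than chloro. As far as these compounds go, it remains open whether a free amine, a carboxylic acid or a longer chain on this aromatic carbon would move the number further in either direction.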